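The compounds below may be only part of what the source reports. "The series", "measured", "known", "first", "only" and "open" are said of these compounds alone.

In an assay on cells with melanin-concentrating hormone receptor 1 (Homo sapiens) as the target, read by radioligand binding (on this read-out higher numbers stand for weaker inhibition and lower numbers for stronger inhibition), compound 3 `CCCCOc1cccc2ccc(N)nc12` gives 789 nM, which sits at the upper end of the two numbers shown. Its nearest neighbour is compound 2 `CC(C)Oc1cccc2ccc(N)nc12`, which gives 437 nM; the step of a 1.8-fold higher number from compound 2 to compound 3 (0.26 log units; within the scatter) is within the scatter, so the two read as much the same. For compound 1 `Nc1ccc2cccc(OC3CCC3)c2n1` the assay reports a limit rather than a number, > 2000 nM (the limit of > 2000 nM in this assay, at which 1 of the 3 values shown sits). Compound 4 `CSCCOc1cccc2ccc(N)nc12` has not yet been measured; it differs from compound 3 by methylsulfanyl in place of ethyl on a saturated chain carbon, two bonds along the chain from an oxygen on an aromatic ring. The measured steps that bear on this change are the ones that alter the group on the oxygen on the aromatic ring: an at least 2.5-fold lower number from compound 1 to compound 3 (0.40 log units; beyond the scatter) and a 1.8-fold higher number from compound 2 to compound 3 (0.26 log units; within the scatter). Within the data shown here, both swap one small carbon group for another, and the second lies within the scatter; none of the measured steps puts a sulfur into the chain, so there is no direct guide. The expected step of a 1.2-fold lower number from compound 3 to compound 4 (0.08 log units; within the scatter) is therefore small, in either direction. Compound 4 is estimated at 650 nM, with a range of 220 nM to 1900 nM.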

Compound 4, half-maximal inhibitory concentration: > 2000 nM
Compound 4: only a limit was reported (the forecaster's own chance of this, stated with the estimate: 12%); middle value at least 3.0-fold (0.48 log units) away from the limit.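

In this assay, the chain on the oxygen proves sensitive to a single atom: methylsulfanyl and ethyl both count 2 heavy atoms, yet the swap gives an at least 2.5-fold higher number from compound 3 to compound 4 (0.40 log units; beyond the scatter). Set against the branched chain, 2-(methylsulfanyl)ethyl in place of isopropyl gives an at least 4.5-fold higher number from compound 2 to compound 4 (0.66 log units; beyond the scatter), so a sulfur in the chain is not tolerated as the butyl chain of compound 3 is. Compound 4 carries a limit rather than a number, the same one as compound 1: the limit of > 2000 nM in this assay, at which 2 of the 4 values shown sit.

As far as these compounds go, the step between compound 1 and compound 4 cannot be read, as both are limits, and how far compound 4 lies past its limit stays unknown. Also open, from the compounds shown here alone, is whether the sulfur itself matters, which a 2-methoxyethyl group, with oxygen in its place, or a longer chain holding sulfur would help to test.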